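Cytotoxicity notes: amide-side swaps on a shared core

The compounds below may be only part of what the source reports. "The series", "measured", "known", "first", "only" and "open" are said of these compounds alone.

Compound 1 `C[C@H](NC(=O)[C@@]1(Cc2ccccc2)CCN1C(=O)OCc1ccccc1)C(=O)NC(C)(C)C` has been tested in an ADME assay on HELF cells (Homo sapiens) for cytotoxicity, with a stated time of 3 days; on this read-out higher numbers stand for lower toxicity in this test and lower numbers for higher toxicity in this test. In this assay compound 1 gives > 100000 nM, which is a limit of the assay and not a number. Compound 2 `C[C@H](NC(=O)[C@]1(Cc2ccccc2)CCN1C(=O)OCc1ccccc1)C(=O)NC1CCCCC1` gives > 100000 nM, likewise a limit. Compound 3 `CC(C)CNC(=O)[C@H](C)NC(=O)[C@]1(Cc2ccccc2)CCN1C(=O)OCc1ccccc1` gives > 100000 nM, again a limit. The step that the two limits leave unreadable from compound 2 to compound 3 is accordingly unreadable, and all three values sit at the limit of > 100000 nM in this assay, at which 3 of the 3 values shown sit. Compound 4 `CC(C)C[C@H](NC(=O)[C@@]1(Cc2ccccc2)CCN1C(=O)OCc1ccccc1)C(N)=O` is not yet measured; it differs from compound 1 by 1-carbamoyl-3-methylbutyl in place of 1-((tert-butyl)carbamoyl)ethyl on an amide-type nitrogen. Among the compounds with values here, no measured step bears directly on this change, and the only available step, from compound 2 to compound 3, cannot be sized, so no shift beyond the scatter is expected. Compound 4 is estimated at 100000 nM, with a range of 40000 nM to 250000 nM, an expected step of a number no higher from compound 1 to compound 4 (the limit leaves the size open).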

Compound 4, half-maximal cytotoxic concentration: 66000 nM
Estimate against measurement, compound 4: 1.5-fold (0.18 log units) above; measured number inside the range.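

On the amide-type nitrogen, 1-carbamoyl-3-methylbutyl in place of 1-((tert-butyl)carbamoyl)ethyl gives an at least 1.5-fold lower number from compound 1 to compound 4 (0.18 log units; that floor lies within the scatter) in this assay. Compound 4 is the only compound shown with a number instead of a limit in this assay: the limit of > 100000 nM in this assay, at which 3 of the 4 values shown sit. The true size of this step stays unknown, and nothing shown places it beyond the scatter.

On these data alone, whether a carboxylic acid or an amine in place of the carbamoyl group, or a longer chain at this position, would move the read-out beyond the scatter remains open.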